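Series notes: urea-to-amide change at the carbonyl

The compounds below may be only part of what the source reports. "The series", "measured", "known", "first", "only" and "open" are said of these compounds alone.

Measured compounds and values:
compound 1 `O=C(Nc1cccc(-n2cc(-c3ccncc3)c(-c3cc(O)cc(Cl)c3)n2)c1)Nc1ccc(Cl)c(C(F)(F)F)c1` gives 91%
compound 2 `COc1cc(Cl)cc(-c2nn(-c3cccc(NC(=O)Nc4ccc(Cl)c(C(F)(F)F)c4)c3)cc2-c2ccncc2)c1` gives 98%
compound 3 `COc1cc(Cl)cc(-c2nn(-c3cccc(NC(=O)Nc4ccc(Cl)c(Cl)c4)c3)cc2-c2ccncc2)c1` gives 94%

All three values come from a functional assay on T47D cells (Homo sapiens) for inhibition, read by sulforhodamine B assay, with a stated time of 48 h, tested at 0.01 uM; a higher number here means a weaker effect of the compound at the concentration tested, a lower number a stronger effect. Compound 2 has the highest number of the three, but its nearest neighbour, compound 3, and its furthest, compound 1, both lie within the scatter of it, so no order among them can be claimed; at this concentration all three show only a weak effect.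

The two measured steps are small: a number 7 percentage points higher from compound 1 to compound 2 (within the scatter) and a number 4 percentage points lower from compound 2 to compound 3 (within the scatter), both within the scatter.

Compound 4 `COc1cc(Cl)cc(-c2nn(-c3cccc(NC(=O)c4cccc(C(F)(F)F)c4)c3)cc2-c2ccncc2)c1` is not yet measured. It differs from compound 2 by 3-(trifluoromethyl)phenyl in place of (4-chloro-3-(trifluoromethyl)phenyl)amino on a carbonyl carbon on a carbonyl carbon whose other neighbour is an amide-type nitrogen. Neither measured step touches this carbonyl carbon or removes a (4-chloro-3-(trifluoromethyl)phenyl)amino group, so nothing measured bears directly on the change. Given that every change so far stayed within the scatter, the step from compound 2 to compound 4 is expected to be a number 3 percentage points lower from compound 2 to compound 4 (within the scatter), with no shift beyond the scatter. Compound 4 is therefore estimated at 95%, in the range 84% to 104%.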

Compound 4, a percentage reported as activity, at one concentration (the size of the read-out at that concentration, not a potency): 99%
Compound 4: the middle estimate sits 4 percentage points below what was measured, and the stated range covers the measured number.
By their numbers in this assay, from the lowest: compounds 1, 3, 2 and 4 (each within the scatter of the next).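

In this assay, among the compounds shown here, the carbonyl carbon now has a measured change for the first time: 3-(trifluoromethyl)phenyl in place of (4-chloro-3-(trifluoromethyl)phenyl)amino gives a number 1 percentage points higher from compound 2 to compound 4 (within the scatter), and 3-(trifluoromethyl)phenyl in place of (3,4-dichlorophenyl)amino gives a number 5 percentage points higher from compound 3 to compound 4 (within the scatter). Both steps lie within the scatter, so at this concentration the urea-to-amide change cannot be told apart from no change in either pair. No available evidence explains these steps.

Each step replaces the amino nitrogen and removes a chloro group at once, so the two changes cannot be separated here. From the compounds shown here alone, it also remains open whether urea and amide would differ at concentrations where the read-out shows a stronger effect, and what a piperidine on this carbonyl carbon would give.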